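The source may report more compounds than this note shows. Statements on the series, on what has been measured and on what is new or still open speak of the compounds shown alone.

In a functional assay on FaDu cells (Homo sapiens) for cytotoxicity, read by MTT assay, with a stated time of 72 h (a lower number here means that less compound is tolerated, a higher number that more compound is tolerated), compound 1 `CC(C)n1cc(C(=O)C(=O)Nc2ccc(C(F)(F)F)nc2)c2ccccc21` gives only a limit, > 10000 nM. Compound 2 `COc1ccc(NC(=O)C(=O)c2cn(C(C)C)c3ccccc23)cn1` gives 85 nM in this assay, and compound 3 `CCCCn1cc(C(=O)C(=O)Nc2ccc(OC)nc2)c2ccccc21` gives 18 nM. Among the measured compounds shown here, the first of the two changes between them is large: an at least 110-fold lower number from compound 1 to compound 2 (2.07 log units; beyond the scatter). The second, the one that bears on what follows, is modest: a 4.7-fold lower number from compound 2 to compound 3 (0.67 log units; beyond the scatter). Compound 3 therefore stands at the lowest of the two numbers, with compound 2 nearest and the step between them beyond the scatter. Compound 4 `COc1ccc(NC(=O)C(=O)c2cn(CC(C)C)c3ccccc23)cn1` comes next: isopropyl in place of propyl on a saturated chain carbon bound to an aromatic nitrogen. Read one bond further out, this is butyl to isobutyl, so compound 4 carries the chain length of compound 3 together with the branching of compound 2. For the measured compounds named here, since the only measured change at this place was modest, a small step is expected, a 1.7-fold higher number from compound 3 to compound 4 (0.22 log units; within the scatter), most likely toward a somewhat higher number. The estimate for compound 4 in this assay is 30 nM, within a range from 10 nM to 90 nM.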

Compound 4, concentration lethal to 50% of the cells: 317 nM
Beside the measured number, compound 4's estimate is 11-fold (1.02 log units) below it; the measured number lies above the stated range.
By their numbers in this assay, from the lowest: compound 3; then compound 2; then compound 4. At a limit, above all of these: compound 1.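

In this assay, the shape of the chain on this aromatic nitrogen counts, not only its size: with the same atoms joined differently, the change from butyl to isobutyl gives an 18-fold higher number from compound 3 to compound 4 (1.25 log units; beyond the scatter). Lengthening isopropyl to isobutyl also raises the number, giving a 3.7-fold higher number from compound 2 to compound 4 (0.57 log units; beyond the scatter), whereas the straight butyl chain of compound 3 had lowered it, so adding carbon to this chain does not by itself lower the number. Nothing measured here explains why the branched chain behaves this way.

As far as these compounds go, it remains open whether a longer straight chain such as pentyl would lower the number further, or whether a chain ending in an amine or a carboxylic acid would be tolerated differently. From the compounds shown here alone, the trifluoromethyl group of compound 1 also remains untested alongside a butyl chain.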